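Swapping thiazole for imidazole in the acrylic acid series

The source may report more compounds than this note shows. Statements on the series, on what has been measured and on what is new or still open speak of the compounds shown alone.

In a functional assay on MCF7 cells (Homo sapiens) for antiproliferative activity, read by CellTiter-Glo, with a stated time of 5 days (on this read-out higher numbers stand for weaker inhibition and lower numbers for stronger inhibition), compound 1 (`CC/C(=C(/c1ccc(/C=C/C(=O)O)cc1)c1ccc2c(cnn2C)c1)c1ccccc1`) gives 300 nM and compound 3 (`CC/C(=C(/c1ccc(/C=C/C(=O)O)cc1)c1ccc(-c2nccs2)cc1)c1ccccc1`) gives 290 nM, two values within the scatter of each other. Compound 2 (`CC/C(=C(/c1ccc(/C=C/C(=O)O)cc1)c1ccc2sncc2c1)c1ccccc1`) gives > 500 nM in this assay, which is a limit and not a number. Compound 4 (`CC/C(=C(/c1ccc(/C=C/C(=O)O)cc1)c1ccc(-n2ccnc2)cc1)c1ccccc1`) carries 1H-imidazol-1-yl in place of 1,3-thiazol-2-yl on an aromatic carbon. Among the measured compounds shown here, the only measured step, an at least 1.6-fold higher number from compound 1 to compound 2 (0.22 log units; that floor lies within the scatter), exchanges a different group and bears on this change only loosely. No step beyond the scatter is therefore expected in this assay, and the expected step is a 1.2-fold higher number from compound 3 to compound 4 (0.07 log units; within the scatter). For compound 4 the estimate is 340 nM, with an expected range of 160 nM to 700 nM.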

Compound 4, half-maximal inhibitory concentration: 380 nM
Compound 4: middle estimate off by 1.1-fold (0.05 log units), on the low side; the range from low to high includes it.
By their numbers in this assay, from the lowest: compounds 3, 1 and 4 (each within the scatter of the next). At a limit, above all of these: compound 2.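

Para to a large group, 1H-imidazol-1-yl in place of 1,3-thiazol-2-yl gives a 1.3-fold higher number from compound 3 to compound 4 (0.12 log units; within the scatter) in this assay. At this position, two five-membered aromatic rings with 2 hetero atoms, one bound through carbon and one through nitrogen, therefore read alike. Any marked loss from this level would soon leave the measurable range, as little room remains up to the assay limit: the limit of > 500 nM in this assay, at which 1 of the 4 values shown sits.

Still open, going by these compounds, is whether an amine or a pyridin-2-yl ring at this position would hold this level. Equally open, on these data alone, is whether a smaller group, such as methoxy, would do so.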